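The source may report more compounds than this note shows. Statements on the series, on what has been measured and on what is new or still open speak of the compounds shown alone.

In a functional assay on HL-60 cells (Homo sapiens) for antiproliferative activity, read by MTT assay, with a stated time of 48 h (a lower number here means a stronger inhibitor, a higher number a weaker inhibitor), compound 1 `N#Cc1nc2c(-c3nc4ccccc4[nH]3)c(N)n(CCN3CCCC3)c2nc1C#N` gives 4760 nM and compound 2 `CN(C)CCCn1c(N)c(-c2nc3ccccc3[nH]2)c2nc(C#N)c(C#N)nc21` gives 870 nM, the lower of these two numbers. Compound 3 `CCN(CC)CCCn1c(N)c(-c2nc3ccccc3[nH]2)c2nc(C#N)c(C#N)nc21` reads > 730 nM, which is a limit and not a number. Compound 4 `CN(C)CCCn1c(N)c(-c2nc3ccccc3n2C)c2nc(C#N)c(C#N)nc21` differs from compound 2 by methyl in place of hydrogen on an aromatic nitrogen. Within the data shown here, no measured step touches that nitrogen. Among the measured compounds shown here, the only readable step, a 5.5-fold lower number from compound 1 to compound 2 (0.74 log units; beyond the scatter), lies in the amine on the chain, so it shows what a change elsewhere can reach and gives no direction here. No step beyond the scatter is therefore expected in this assay. The estimated step is a 1.1-fold higher number from compound 2 to compound 4 (0.06 log units; within the scatter). For compound 4 the estimated value is 1000 nM, with an expected range of 300 nM to 3300 nM.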

Compound 4, half-maximal inhibitory concentration: 2120 nM
Compound 4: middle estimate off by 2.1-fold (0.33 log units), on the low side; the measured number falls inside the stated range.
By their numbers in this assay, from the lowest: compound 2; then compound 4; then compound 1.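

In this assay, among these compounds, the step of a 2.4-fold higher number from compound 2 to compound 4 (0.39 log units; beyond the scatter) is the first reading at this aromatic nitrogen, and it runs toward weaker activity, a direction the chain amine changes could not show for this position. It rests on a single pair, so methyl in place of hydrogen is known only with the dimethylamino chain. As far as these compounds go, whether ethyl or a longer alkyl chain on that nitrogen would go the same way stays open. Steps to compound 3 cannot be read because its value is a limit: the limit of > 730 nM in this assay, at which 1 of the 4 values shown sits.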